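The source may report more compounds than this note shows. Statements on the series, on what has been measured and on what is new or still open speak of the compounds shown alone.

Measured compounds:
compound 1, `Nc1ncn(CCC2(N)OC(=O)C(OCc3ccccc3)=C2OCc2ccccc2)c(=O)n1`, > 100000 nM
compound 2, `Nc1ncn(C/C=C2\OC(=O)C(OCc3ccccc3)=C2OCc2ccccc2)c(=O)n1`, 5620 nM
compound 3, `O=C1O[C@H]([C@@H](O)Cn2ccc(NC(=O)c3ccccc3)nc2=O)C(OCc2ccccc2)=C1OCc1ccccc1`, > 100000 nM

In a functional assay on SW-620 cells (Homo sapiens) for inhibition, read by MTT assay, with a stated time of 72 h (a lower number here means a stronger inhibitor, a higher number a weaker inhibitor), compound 1 gives no number, only a limit of the assay, > 100000 nM. Compound 3 likewise reaches only a limit in this assay, > 100000 nM. Among the measured compounds shown here, compound 2, the one member of the set with an exocyclic double bond to the core, is the only compound with a measured value in this assay, and gives 5620 nM. Compound 1 therefore stands at the limit of > 100000 nM in this assay, at which 2 of the 3 values shown sit, and nothing in the numbers places it above or below compound 3.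

Compound 4, `Cc1cn(CCC2(N)OC(=O)C(OCc3ccccc3)=C2OCc2ccccc2)c(=O)[nH]c1=O`, differs from compound 1 in one place: a group of 9 heavy atoms (5 carbon, 2 nitrogen, 2 oxygen; one six-membered aromatic ring with 2 hetero atoms) in place of a group of 8 heavy atoms (3 carbon, 4 nitrogen, 1 oxygen; one six-membered aromatic ring with 3 hetero atoms), on a saturated chain carbon, two bonds along the chain from a saturated ring carbon. For the measured compounds named here, no step between two measured compounds runs across this change, so its effect in this assay has not been seen. Compound 1 offers only a limit as a starting point, and compound 3, which carries a different ring of this kind on a saturated chain beside a saturated core carbon, also sits at the same limit. The expected step from compound 1 to compound 4, a number no higher from compound 1 to compound 4 (the limit leaves the size open), is therefore none beyond the scatter, with compound 4 expected to remain at the limit in most repeats. The estimate for compound 4 in this assay is 100000 nM, in a range from 30000 nM to 300000 nM.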

Compound 4, half-maximal inhibitory concentration: > 100000 nM
Compound 4: only a limit was reported; the forecaster's own chance of this, stated with the estimate: 70%; the middle value sits exactly at the limit.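

In this assay compound 4 gives > 100000 nM, which is a limit of the assay and not a number. Among the compounds shown here, compound 1 also reaches only a limit, so no step between compound 1 and compound 4 can be read. Left open is whether compound 1 or compound 4 would give a measurable value in this assay, and so how the two compare: the limit of > 100000 nM in this assay, at which 3 of the 4 values shown sit.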